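Working notes: the group on the amine nitrogen

The source may hold more compounds than are shown below. What is called first, only, known or untested is meant among the compounds shown, and "the series" means these compounds.

- compound 1 `O=C1C=C(Nc2ccc(Br)cc2)C(=O)c2c1nc1n2[C@H]2OC[C@@H](O)[C@H]2OC1` gives 2580 nM in a functional assay on MCF7 cells (Homo sapiens) for inhibition, read by sulforhodamine B assay; a lower number here means a stronger inhibitor, a higher number a weaker inhibitor
- compound 2 `Cc1ccc(NC2=CC(=O)c3nc4n(c3C2=O)[C@H]2OC[C@@H](O)[C@H]2OC4)cc1C` gives 2080 nM in this assay

Compound 2 and compound 1 sit within the scatter of each other, so neither ranks ahead. Compound 3 `COc1cccc(NC2=CC(=O)c3nc4n(c3C2=O)[C@H]2OC[C@@H](O)[C@H]2OC4)c1` carries 3-methoxyphenyl in place of 3,4-dimethylphenyl on an amine nitrogen, with 3-methoxyphenyl in place of 3,4-dimethylphenyl on an amine nitrogen as the counted change. For the measured compounds named here, the one measured step bearing on this is a 1.2-fold lower number from compound 1 to compound 2 (0.09 log units; within the scatter) for a change on the same amine nitrogen. On that single step, no shift beyond the scatter is expected in this assay for the new change. The expected step is a 1.1-fold higher number from compound 2 to compound 3 (0.04 log units; within the scatter) in size. In this assay compound 3 is expected at 2300 nM with an estimated range from 1000 nM to 5500 nM around it.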

Compound 3, half-maximal inhibitory concentration: > 4000 nM
Compound 3: a limit, no number; the forecaster's own chance of this, stated with the estimate: 3%; middle value at least 1.7-fold (0.24 log units) from the limit.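

Compound 3 gives a limit, not a number, in this assay: the limit of > 4000 nM in this assay, at which 1 of the 3 values shown sits.

The steps read as an at least 1.9-fold higher number from compound 2 to compound 3 (0.28 log units; that floor lies within the scatter) and an at least 1.5-fold higher number from compound 1 to compound 3 (0.19 log units; that floor lies within the scatter), so these floors do not separate 3-methoxyphenyl from the two earlier groups on the amine nitrogen. Unlike those groups, it brings a hydrogen-bond acceptor, but the size of this change can only be given as a floor.

As far as these compounds go, it remains open how the true value of compound 3 compares with the other two, and how a cyclohexyl group or a simple alkyl chain on the amine nitrogen would read in this assay.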